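Swapping Phenoxy for Chloro on a Fluorinated Core

The source may report more compounds than this note shows. Statements on the series, on what has been measured and on what is new or still open speak of the compounds shown alone.

Compound 1 `CCOC(=O)c1c(-c2cccc(Oc3ccccc3)c2)[nH]c2cc(OC)ccc2c1=O` and compound 2 `CCOC(=O)c1c(-c2cccc(Cl)c2)[nH]c2cc(OC)ccc2c1=O` share a core and differ only in one group: chloro in place of phenoxy on an aromatic carbon. In an ADME assay for permeability, using PAMPA, at pH 7.4 (a higher number here means that the compound crosses the layer faster, a lower number that the compound crosses the layer more slowly), compound 1 gives 750 10^-6 cm/s, while compound 2 gives 950 10^-6 cm/s, so this change produced a 1.3-fold higher number from compound 1 to compound 2 (0.10 log units; within the scatter). Compound 3 `CCOC(=O)c1c(-c2cccc(Oc3ccccc3)c2)[nH]c2cc(OC)c(F)cc2c1=O` keeps the phenoxy group of compound 1, but its core is altered by fluoro in place of hydrogen on an aromatic carbon. In this assay compound 3 gives 560 10^-6 cm/s, which amounts to a 1.3-fold lower number from compound 1 to compound 3 (0.13 log units; within the scatter). Among the three measured compounds, all the differences fall within the usual scatter of repeated measurements, so none of them can be said to cross the layer faster or slower than another.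

Compound 4 `CCOC(=O)c1c(-c2cccc(Cl)c2)[nH]c2cc(OC)c(F)cc2c1=O` has not yet been measured. It differs from compound 3 by chloro in place of phenoxy on an aromatic carbon, which is the same change, at the same place, that separates compound 1 from compound 2. Among the measured compounds shown here, the only guide to its outcome is that earlier pair. The step from compound 3 to compound 4 in this assay is expected to be a 1.3-fold higher number from compound 3 to compound 4 (0.11 log units; within the scatter), resting on the earlier step because the change from phenoxy to chloro gave a 1.3-fold higher number from compound 1 to compound 2 (0.10 log units; within the scatter). Compound 4 is therefore expected to give about 720 10^-6 cm/s in this assay, most likely falling between 450 10^-6 cm/s and 1100 10^-6 cm/s.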

Compound 4, apparent permeability in the ADME assay: 410 10^-6 cm/s
Compound 4: the middle estimate sits 1.8-fold (0.24 log units) above what was measured, and the stated range ends above it.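

In the ADME assay, chloro in place of phenoxy on the fluorinated core gives a 1.4-fold lower number from compound 3 to compound 4 (0.14 log units; within the scatter), and this step does not differ measurably from the one seen on the core of compound 1: the same change on two cores in the ADME assay, a 1.3-fold higher number (0.10 log units; within the scatter) from compound 1 to compound 2 and a 1.4-fold lower number (0.14 log units; within the scatter) from compound 3 to compound 4, 1.7-fold (0.24 log units) apart, within the scatter of two such steps. Fluoro in place of hydrogen, now read on the chloro compounds, gives a 2.3-fold lower number from compound 2 to compound 4 (0.36 log units; beyond the scatter), which passes beyond the scatter where the phenoxy pair did not, yet the two steps cannot be told apart: the same change on two cores in the ADME assay, a 1.3-fold lower number (0.13 log units; within the scatter) from compound 1 to compound 3 and a 2.3-fold lower number (0.36 log units; beyond the scatter) from compound 2 to compound 4, 1.7-fold (0.24 log units) apart, within the scatter of two such steps. So each change can be carried from one core to the other without any measurable difference in its step, but this rests on a single pair of steps per change, and it does not show that the phenoxy-to-chloro change moves this number in either direction or that the fluoro step truly grows on the chloro compounds.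

In a physicochemical assay for solubility, at pH 7.4 (a lower number here means a less soluble compound, a higher number a more soluble compound), compound 3 gives 4300 nM and compound 4 gives 20000 nM. For the physicochemical assay, only one pair is shown, so whether the higher number seen with chloro in place of phenoxy also holds on the core of compound 1 stays open: the measured solubility of compound 3, 4300 nM, and of compound 4, 20000 nM, a 4.7-fold higher number (0.67 log units; beyond the scatter). Going by these compounds, it also remains open how an amine, a carboxylic acid or a bromo group in the place of chloro would behave in either assay.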